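The compounds below may be only part of what the source reports. "The series", "measured", "known", "first", "only" and "open" are said of these compounds alone.

Values in a functional assay on MDA-MB-231 cells (Homo sapiens) for cytotoxicity, read by MTT assay, with a stated time of 72 h; on this read-out higher numbers stand for weaker inhibition and lower numbers for stronger inhibition:
- Compound 1 `O=C1c2c[n+]([O-])c3ccccc3c2C(=O)c2c1c1ccccc1n2Cc1cn([C@@H]2C[C@H](O)[C@@H](CO)O2)nn1`: 130 nM
- Compound 2 `CN1CCN(CCCCCCn2c3c(c4ccccc42)C(=O)c2c[n+]([O-])c4ccccc4c2C3=O)CC1`: 2400 nM
- Compound 3 `CN(C)CCCCn1c2c(c3ccccc31)C(=O)c1c[n+]([O-])c3ccccc3c1C2=O`: 350 nM

Compound 1 holds the lowest number of the three, with compound 3 next and compound 2 furthest from it. Compound 4 `O=C1c2c[n+]([O-])c3ccccc3c2C(=O)c2c1c1ccccc1n2Cc1cn([C@@H]2O[C@H](CO)[C@@H](O)[C@H](O)[C@H]2O)nn1` has not yet been measured. It keeps the core of compound 1 and carries 3,4,5-trihydroxy-6-(hydroxymethyl)oxan-2-yl in place of 4-hydroxy-5-(hydroxymethyl)oxolan-2-yl, on an aromatic nitrogen of a five-membered aromatic ring with 3 nitrogen: 3,4,5-trihydroxy-6-(hydroxymethyl)oxan-2-yl in place of 4-hydroxy-5-(hydroxymethyl)oxolan-2-yl on an aromatic nitrogen.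

Among the compounds with values here, only one measured step is available, a 6.9-fold lower number from compound 2 to compound 3 (0.84 log units; beyond the scatter). Within the data shown here, it concerns a different side group, and no measurement yet exchanges either of these two rings, so it offers a rough scale and no direct precedent. In that single pair, the compound with the larger end group, compound 2 at 2400 nM, has the higher number. On that thin basis, a modest rise is expected, smaller than that step and possibly within the scatter.

The expected change is a 2.3-fold higher number from compound 1 to compound 4 (0.36 log units; beyond the scatter). For compound 4, the estimated value in this assay is 300 nM, with an expected range of 90 nM to 1000 nM.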

Compound 4, half-maximal inhibitory concentration: 650 nM
The estimate for compound 4 lay 2.2-fold (0.34 log units) below the measured number; low and high end bracket the measured number.
By their numbers in this assay, from the lowest: compound 1; then compounds 3 and 4 (each within the scatter of the next); then compound 2.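

In this assay, 3,4,5-trihydroxy-6-(hydroxymethyl)oxan-2-yl in place of 4-hydroxy-5-(hydroxymethyl)oxolan-2-yl on an aromatic nitrogen of the five-membered aromatic ring with 3 nitrogen gives a 5.0-fold higher number from compound 1 to compound 4 (0.70 log units; beyond the scatter), so the number responds to the group carried at this position, and the change is a modest one. The entering group has more heavy atoms, hydrogen-bond donors and hydrogen-bond acceptors, and the compound carrying it has the higher number; the same direction with end-group size appears in the step at a different side group, a 6.9-fold lower number from compound 2 to compound 3 (0.84 log units; beyond the scatter), and neither pair goes against it, though two pairs at separate positions make only a thin pattern. No measurement is available that accounts for the rise at this position.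

Ring size, the number of hydroxyl groups and the number of stereocentres all change together in this single exchange, so the compounds shown do not separate their contributions. Also open, on these data alone, is how the number moves with a group of another kind on that nitrogen, such as a hydroxyethyl chain or a carboxylic acid.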